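The compounds below may be only part of what the source reports. "The series", "measured", "known", "first", "only" and "open" are said of these compounds alone.

In a functional assay on HL-60 cells (Homo sapiens) for cytotoxicity, read by MTT assay, with a stated time of 72 h (on this read-out lower numbers stand for stronger inhibition and higher numbers for weaker inhibition), compound 3 `COc1ccc(S(=O)(=O)c2nc3ccccc3nc2Nc2cc(OC)cc(OC)c2)cc1` gives 1710 nM. Compound 1 `COc1cc(Nc2nc3ccccc3nc2S(=O)(=O)c2ccccc2)cc(OC)c1OC` gives 1770 nM in this assay, a number within the usual scatter of that of compound 3, while compound 2 `COc1cc(Nc2nc3ccccc3nc2S(=O)(=O)c2ccc(C)cc2)cc(OC)c1OC` gives 320 nM, lower than both of them. Compound 4 `COc1ccc(S(=O)(=O)c2nc3ccccc3nc2Nc2cc(OC)c(OC)c(OC)c2)cc1` differs from compound 3 by methoxy in place of hydrogen on an aromatic carbon. Among the measured compounds shown here, the only measured single change, a 5.5-fold lower number from compound 1 to compound 2 (0.74 log units; beyond the scatter), is a different kind of change, a methyl in place of hydrogen on an aromatic carbon, so no measured step bears directly on adding a methoxy. With that gap in the data, a moderate movement toward lower numbers is expected, but with wide uncertainty; the expected step is a 2.9-fold lower number from compound 3 to compound 4 (0.45 log units; beyond the scatter). For compound 4 the estimate in this assay is 600 nM, with a range from 150 nM to 2400 nM.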

Compound 4, half-maximal inhibitory concentration: 680 nM
Compound 4: middle estimate off by 1.1-fold (0.05 log units), on the low side; measured number inside the range.
By their numbers in this assay, from the lowest: compound 2; then compound 4; then compounds 3 and 1 (each within the scatter of the next).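

In this assay, among the compounds shown here, a methoxy placed ortho to two methoxy groups and para to a large group gives a 2.5-fold lower number from compound 3 to compound 4 (0.40 log units; beyond the scatter), the first measured step for this group. The same exchange of hydrogen for methoxy at another place in the molecule gives a 2.6-fold lower number from compound 1 to compound 4 (0.42 log units; beyond the scatter), so that change also lowers the number there. At that second place, methyl and methoxy can be compared directly, with a 2.1-fold higher number from compound 2 to compound 4 (0.33 log units; beyond the scatter), so methoxy gives the higher number. On these data alone, whether an amine or a chlorine would give a lower number at either place stays open. No measurement at hand explains these steps.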